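A few compounds are considered here, and "the series" means these few. Any claim that something is new, unique, unknown or untested is made for them only; others in the source may bear on it.

Series notes. Compound 1 `Cc1cc(F)ccc1C1=Nc2c(Br)cccc2SC(C(=O)O)C1` stands only at a limit in an ADME assay on NCTC-2544 cells (Homo sapiens, culture collection number NCTC 2544), read by MTT assay, with a stated time of 72 h; a lower number here means a stronger inhibitor of growth, a higher number a weaker inhibitor of growth: it returned > 20000000 nM, a limit of the assay and not a number, as the limit of > 20000000 nM in this assay, at which 1 of the 2 values shown sits, records. Compound 2 `Cc1cc(F)ccc1C1=Nc2c(F)cccc2SC(C(=O)O)C1` carries fluoro at the same place, and in this assay compound 2 gives 2600000 nM; 2600000 nM (2 entries), twice in agreement. Among the compounds with values here, the two values shown thus differ in kind, one a number and one a limit, so no step between measured compounds can be stated. Compound 3 `Cc1cc(F)ccc1C1=Nc2c(Cl)cccc2SC(C(=O)O)C1` is still to be measured in this assay. It differs from compound 1 by chloro in place of bromo on an aromatic carbon. With compound 1 at a limit and compound 2 at a number, compound 3 is expected to land between the two, with the step of an at least 2.5-fold lower number from compound 1 to compound 3 (0.39 log units; beyond the scatter) expected to run toward a stronger reading, though another limit remains quite possible. Compound 3 is therefore estimated at 8000000 nM, with a range of 2500000 nM to 25000000 nM.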

Compound 3, concentration for 50% growth inhibition: 6900000 nM
Beside the measured number, compound 3's estimate is 1.2-fold (0.06 log units) above it; the range from low to high includes it.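

Chloro in place of bromo on an aromatic carbon brings this position from a limit to a number in this assay, an at least 2.8-fold lower number from compound 1 to compound 3 (0.46 log units; beyond the scatter). From the compounds shown here alone, the value for compound 1 is a limit of the assay and not a number, so this step gives only a bound and its full size stays unknown: the limit of > 20000000 nM in this assay, at which 1 of the 3 values shown sits. Chloro in compound 3 now joins fluoro in compound 2 as a group at this place that returns a number, so the position no longer rests on a single measured halogen.

The compounds shown leave open how a methoxy group, an amine or plain hydrogen at this place would read in this assay. They also leave open whether the step from bromo to chloro would hold on a core with an amide in place of the carboxylic acid.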